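Trimming a Trimethylphenyl Group on a Disulfide-Isomerase Inhibitor

The compounds below may be only part of what the source reports. "The series", "measured", "known", "first", "only" and "open" are said of these compounds alone.

Of the compounds shown here, three have been measured in an assay for inhibition of protein disulfide-isomerase (Homo sapiens), with a stated time of 1 h; on this read-out higher numbers stand for weaker inhibition and lower numbers for stronger inhibition. Compound 1, `Oc1c(C(c2ccc(F)cc2)N2CCCCC2)ccc2cncnc12`, gives 4860 nM in this assay. Compound 2, `Oc1ccc2scnc2c1C(c1ccc(F)cc1)N1CCCCC1`, reaches only the limit of the assay, > 100000 nM, so no number is known for it. Compound 3, `Cc1cc(C)c(C(Nc2ccccn2)c2ccc3cccnc3c2O)c(C)c1`, gives 190 nM in this assay, the lowest number among the measured compounds; the number for compound 1 lies higher, and that gap is beyond the scatter. For the measured compounds named here, since no two measured compounds differ in one place only, no single step has yet been measured.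

Compound 4, `Cc1ccc(C)c(C(Nc2ccccn2)c2ccc3cccnc3c2O)c1`, has not been measured. It differs from compound 3 in one place: 2,5-dimethylphenyl in place of 2,4,6-trimethylphenyl on a saturated chain carbon bound to an aromatic carbon and a nitrogen on an aromatic ring. Going by the values given here, with no measured step to lean on, the change is expected to cost some potency, with the step from compound 3 to compound 4 in this assay estimated at a 2.1-fold higher number from compound 3 to compound 4 (0.32 log units; beyond the scatter). Compound 4 is therefore estimated to give about 400 nM in this assay, expected to fall between 120 nM and 1300 nM.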

Compound 4, half-maximal inhibitory concentration: 730 nM
Beside the measured number, compound 4's estimate is 1.8-fold (0.26 log units) below it; the range from low to high includes it.
By their numbers in this assay, from the lowest: compound 3; then compound 4; then compound 1. At a limit, above all of these: compound 2.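

For the compounds shown here, this is the first step measured at a single place, and it shows that in this assay the group on the saturated chain carbon bound to an aromatic carbon and a nitrogen on an aromatic ring affects potency: swapping 2,4,6-trimethylphenyl for 2,5-dimethylphenyl gives a 3.8-fold higher number from compound 3 to compound 4 (0.58 log units; beyond the scatter). The step is modest, so the new group costs some potency but still leaves a measured number rather than a limit of the assay. Nothing measured here explains why potency moves with this change.

The swap alters both the number and the placing of the methyl groups on the ring, so this one step cannot separate the two. From the compounds shown here alone, how a plain phenyl ring or a methoxy-bearing phenyl ring would behave at this place remains open.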